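Propyl to isobutyl: compound 3 to compound 4

The source may hold more compounds than are shown below. What is called first, only, known or untested is meant among the compounds shown, and "the series" means these compounds.

Values in a functional assay on K562 cells (Homo sapiens) for antiproliferative activity, read by MTT assay; a higher number here means a weaker inhibitor, a lower number a stronger inhibitor:
compound 1 `COC(=O)N1CCCc2cc(S(=O)(=O)N3CC(c4ccccc4)NC3=O)ccc21`: > 20000 nM
compound 2 `CCOC(=O)N1CCCc2cc(S(=O)(=O)N3CC(c4ccccc4)NC3=O)ccc21`: > 20000 nM
compound 3 `CCCOC(=O)N1CCCc2cc(S(=O)(=O)N3CC(c4ccccc4)NC3=O)ccc21`: > 20000 nM

Compound 3 gives > 20000 nM, which is a limit and not a number. For the measured compounds named here, the series so far stands entirely at the limit of > 20000 nM in this assay, at which 3 of the 3 values shown sit.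

Compound 4 `CC(C)COC(=O)N1CCCc2cc(S(=O)(=O)N3CC(c4ccccc4)NC3=O)ccc21` changes propyl to isobutyl: methyl in place of hydrogen on a saturated chain carbon bound to two saturated chain carbons.

The measured chain steps bearing on this are a step that the two limits leave unreadable from compound 1 to compound 2, a step that the two limits leave unreadable from compound 1 to compound 3 and a step that the two limits leave unreadable from compound 2 to compound 3. None has a readable size, so no step beyond the scatter is expected in this assay, and another limit is the likeliest result.

The expected change is a step that the limit leaves unreadable from compound 3 to compound 4. For compound 4 the estimate is 25000 nM, with an expected range of 12000 nM to 50000 nM.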

Compound 4, half-maximal inhibitory concentration: 2380 nM
Compound 4: the middle estimate sits 11-fold (1.02 log units) above what was measured; measured number outside the range, below it.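

In this assay this position gives its first readable result, with an at least 8.4-fold lower number from compound 3 to compound 4 (0.92 log units; beyond the scatter); the same isobutyl group also gives an at least 8.4-fold lower number from compound 2 to compound 4 (0.92 log units; beyond the scatter) and an at least 8.4-fold lower number from compound 1 to compound 4 (0.92 log units; beyond the scatter). The steps among compound 1, compound 2 and compound 3 cannot be read, so the methyl on a saturated chain carbon bound to two saturated chain carbons is the first change here with a readable effect, and compound 4 alone leaves the limit: the limit of > 20000 nM in this assay, at which 3 of the 4 values shown sit.

Going by these compounds, whether a straight butyl chain would match the isobutyl group stays open. So does the outcome with a tert-butyl group or an amine at this position.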